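A few compounds are considered here, and "the series" means these few. Any claim that something is new, unique, unknown or untested is made for them only; others in the source may bear on it.

Of the compounds shown here, two from this series have so far been tested in a functional assay on SR cells (Homo sapiens) for inhibition, read by sulforhodamine B assay, with a stated time of 48 h, tested at 0.01 uM; a higher number here means a weaker effect of the compound at the concentration tested, a lower number a stronger effect. Compound 1, `COc1cc(Cl)cc(-c2nn(-c3cccc(NC(=O)Nc4cc(C(F)(F)F)cc(C(F)(F)F)c4)c3)cc2-c2ccncc2)c1`, gives 101% in this assay, a number that shows essentially no inhibition at the concentration used. Compound 2, `COc1cc(Cl)cc(-c2nn(-c3cccc(NC(=O)Nc4ccc(Cl)c(Cl)c4)c3)cc2-c2ccncc2)c1`, gives 94% in this assay. On the numbers shown, compound 2 has the smaller of the two readings, but its only neighbour, compound 1, sits within the scatter of it, so the two compounds cannot be told apart and both read as inactive at this concentration.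

Compound 3, `COc1cc(Cl)cc(-c2nn(-c3cccc(NC(=O)Nc4cccc(C(F)(F)F)c4)c3)cc2-c2ccncc2)c1`, has not yet been measured. It differs from compound 2 in one place: 3-(trifluoromethyl)phenyl in place of 3,4-dichlorophenyl on an amide-type nitrogen. Nothing in the two measured compounds suggests that an exchange of this kind moves the reading beyond the scatter, since compound 1 and compound 2 already carry different groups at this same position and give numbers within the scatter of each other. The step expected from compound 2 to compound 3 in this assay is therefore a number 4 percentage points higher from compound 2 to compound 3 (within the scatter), that is, none beyond the scatter. Compound 3 is accordingly expected to give about 98% in this assay, with a likely range from 86% to 110%.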

Compound 3, a percentage reported as activity, at one concentration (the size of the read-out at that concentration, not a potency): 89%
Estimate against measurement, compound 3: 9 percentage points above; low and high end bracket the measured number.
By their numbers in this assay, from the lowest: compounds 3, 2 and 1 (each within the scatter of the next, the first and the last beyond it).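

In this assay the exchange of 3,4-dichlorophenyl for 3-(trifluoromethyl)phenyl on the amide-type nitrogen gives a number 5 percentage points lower from compound 2 to compound 3 (within the scatter) and so leaves this pair indistinguishable, which shows that these two aryl groups cannot be separated at this concentration. Among the compounds shown here, the comparison with hydrogen in place of trifluoromethyl on an aromatic carbon gives a number 12 percentage points lower from compound 1 to compound 3 (beyond the scatter) and is the first step to clear the scatter, so the substitution on this aryl group can shift the reading, if only modestly. Nothing shown gives a measured reason for that shift.

The compounds shown leave open whether the shift continues with the loss of the remaining trifluoromethyl, as in an unsubstituted phenyl, or whether a methoxy group, an amine or a carboxylic acid on this ring would move the reading further. They also leave open how the compounds compare at other concentrations, since a reading at one concentration is not a potency, and a larger effect at this position remains to be seen.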